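A few compounds are considered here, and "the series" means these few. Any claim that something is new, unique, unknown or untested is made for them only; others in the source may bear on it.

Measured in a functional assay on HepG2 cells (Homo sapiens) for antiproliferative activity, read by MTT assay, with a stated time of 48 h; on this read-out lower numbers stand for stronger inhibition and higher numbers for weaker inhibition:
- compound 1 `COc1ccc(N(C)c2ccnc(Cl)n2)cc1OCCCBr`: 1240 nM
- compound 2 `COc1ccc(N(C)c2ccnc(Cl)n2)cc1OCCCCCBr`: > 10000 nM (a limit of the assay, not a number)

Compound 2 sits at the limit of > 10000 nM in this assay, at which 1 of the 2 values shown sits, so its position is known only as a limit.

Next in the series is compound 3 `COc1ccc(N(C)c2ccnc(Cl)n2)cc1OCCC[Se]C#N`, which differs from compound 2 in one place: a group of 3 heavy atoms (1 carbon, 1 nitrogen, 1 selenium; no ring) in place of a group of 3 heavy atoms (2 carbon, 1 bromine; no ring), on a saturated chain carbon, three bonds along the chain from an oxygen on an aromatic ring. 2-bromoethyl leaves, and a group holding selenium and a triple bond outside aromatic rings enters, on a saturated chain carbon, three bonds along the chain from an oxygen on an aromatic ring.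

Among the compounds with values here, one measured step bears on this: an at least 8.0-fold higher number from compound 1 to compound 2 (0.90 log units; beyond the scatter). That step lies beyond the scatter, and it brought in the same 2-bromoethyl that now leaves. Within the data shown here, no selenium-bearing compound has been measured, so the entering group's own contribution is open. Among the measured compounds shown here, with compound 1 at 1240 nM as the only number, a lower number of roughly that size, beyond the scatter, is expected in this assay. The expected change is an at least 11-fold lower number from compound 2 to compound 3 (1.04 log units; beyond the scatter).

For compound 3 the estimate is 900 nM, with an expected range of 150 nM to 5000 nM.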

Compound 3, half-maximal inhibitory concentration: 5150 nM
The estimate for compound 3 lay 5.7-fold (0.76 log units) below the measured number, outside the stated range (above it).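

In this assay, the selenium-bearing group on this saturated chain carbon does not match the bromine it replaces, with a 4.2-fold higher number from compound 1 to compound 3 (0.62 log units; beyond the scatter). Within the data shown here, this is the first number for a group other than a bromine-ended chain at this place, and it shows that the selenium-bearing group keeps a measurable antiproliferative read-out, though a weaker one than the bromine of the shared scaffold gave. Against 2-bromoethyl, the reading is only an at least 1.9-fold lower number from compound 2 to compound 3 (0.28 log units; that floor lies within the scatter), and since that floor lies within the scatter, no gain over 2-bromoethyl can be claimed, as compound 2 carries a limit of the assay and not a number: the limit of > 10000 nM in this assay, at which 1 of the 3 values shown sits.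

Going by these compounds, how a thiocyanate or a simple nitrile on the same chain carbon would compare remains open, so the part played by the selenium atom itself cannot yet be separated from that of the triple bond. Also open, on these data alone, are the selenium-bearing group on a longer chain and an amine in place of the chlorine of the shared core.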